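A few compounds are considered here, and "the series" means these few. Any claim that something is new, unique, unknown or untested is made for them only; others in the source may bear on it.

Working notes on the series. The shared core carries a chain on the saturated chain carbon bound to a nitrogen on an aromatic ring, and so far only that chain has been varied. Compound 1 `CCCN(C1=NCCN1)c1c(Br)cccc1Br` gives 11 in a physicochemical assay for acid dissociation. Compound 2 `C=CCN(C1=NCCN1)c1c(Br)cccc1Br` gives 10.7, and compound 3 `C=C(C)CN(C1=NCCN1)c1c(Br)cccc1Br` gives 10.7. Compound 3 thus stands level with compound 2, the two together the lowest of the three numbers, with compound 1 the furthest away; the step of a number 0.30 log units lower from compound 1 to compound 3 (within the scatter) and the step of no change at the digits printed from compound 2 to compound 3 (within the scatter) are both within the scatter, as is a number 0.30 log units lower from compound 1 to compound 2 (within the scatter).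

The next compound is compound 4 `Brc1cccc(Br)c1N(Cc1ccccc1)C1=NCCN1`. The change from compound 3 is phenyl in place of 1-methylethenyl on a saturated chain carbon bound to a nitrogen on an aromatic ring.

All three measured steps bear on this change, since each of them also swaps the group on the saturated chain carbon bound to a nitrogen on an aromatic ring, and none of them moved this assay beyond the scatter. A larger group enters here than in any measured step, but the data offer nothing to anchor a shift in either direction. The expectation for compound 4 is therefore a step of no change at the digits printed from compound 3 to compound 4 (within the scatter) that stays within the scatter. Compound 4 is estimated at 10.7, with a range from 10.3 to 11.1.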

Compound 4, acid dissociation constant: 10.4
Compound 4: middle estimate off by 0.30 log units, on the high side; the measured number falls inside the stated range.
By their numbers in this assay, from the lowest: compounds 4, 2, 3 and 1 (each within the scatter of the next, the first and the last beyond it).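

In this assay the group on the saturated chain carbon bound to a nitrogen on an aromatic ring now gives its first step beyond the scatter: phenyl in place of ethyl gives a number 0.60 log units lower from compound 1 to compound 4 (beyond the scatter) and is a modest step. The other two new steps, a number 0.30 log units lower from compound 3 to compound 4 (within the scatter) and a number 0.30 log units lower from compound 2 to compound 4 (within the scatter), remain within the scatter, so compound 4 separates from compound 1 only and cannot be told apart from compound 2 or compound 3 in this assay. No measurement on hand accounts for the step from compound 1 to compound 4.

The compounds shown carry only hydrocarbon groups at this position, so it remains open whether a group holding a heteroatom, such as an amine, a methoxy group or a carboxylic acid, would shift the number in this assay in either direction. Also open, as far as these compounds go, are whether a longer chain or a substituted phenyl would extend the step seen with phenyl, and whether that step would persist on a core without the two bromine atoms.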